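A few compounds are considered here, and "the series" means these few. Any claim that something is new, unique, unknown or untested is made for them only; others in the source may bear on it.

Measured so far:
compound 1, `C=CC(=O)Oc1cc(C(F)(F)F)cc(C(F)(F)F)c1`: < 0.017 h
compound 2, `N#Cc1cc(C(F)(F)F)cc(C(F)(F)F)c1`: > 50 h

In an ADME assay for pharmacokinetics, read by HPLC, in phosphate buffer, with a stated time of 72 h, at pH 7.4, tested at 250 uM (on this read-out higher numbers stand for a longer-lived compound and lower numbers for a shorter-lived compound), compound 1 gives < 0.017 h, which is a limit of the assay and not a number (the limit of < 0.017 h in this assay, at which 1 of the 2 values shown sits). Compound 2 gives > 50 h in this assay, again a limit rather than a number (the limit of > 50 h in this assay, at which 1 of the 2 values shown sits). Among the compounds with values here, compound 2 therefore stands only as a bound, and the other value shown is a bound as well, so the one measured step, an at least 2900-fold higher number from compound 1 to compound 2 (3.46 log units; beyond the scatter), is itself only a minimum size. Compound 3 is `O=C(CBr)c1cc(C(F)(F)F)cc(C(F)(F)F)c1`; it differs from compound 2 by (bromomethyl)carbonyl in place of cyano on an aromatic carbon. The measured step concerns the arrival of the cyano group that the new step removes, while the entering group differs, so it bears on the new step only loosely. A downward step beyond the scatter is expected, though smaller than the measured one. Compound 3 is estimated at 15 h in this assay, with a range of 2 h to 80 h, the expected step being an at least 3.3-fold lower number from compound 2 to compound 3 (0.52 log units; beyond the scatter).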

Compound 3, half-life: < 0.017 h
Compound 3 gave a limit, no number (the forecaster's own chance of this, stated with the estimate: 30%); middle value at least 880-fold (2.94 log units) from the limit.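

In this assay compound 3 gives < 0.017 h as a limit of the assay and not a number. On the shared core, at the aromatic carbon meta to two trifluoromethyl groups, (bromomethyl)carbonyl in place of cyano gives an at least 2900-fold lower number from compound 2 to compound 3 (3.46 log units; beyond the scatter) and, like the (vinylcarbonyl)oxy group of compound 1, sits at the short-lived end of the read-out. The step between compound 1 and compound 3 cannot be read, and the step from the nitrile is only a minimum size: the limit of < 0.017 h in this assay, at which 2 of the 3 values shown sit.

All three values shown are limits, so no group here has a half-life inside the range of this assay. Where a methylcarbonyl, a chloromethylcarbonyl, an amide or a carboxylic acid at this position would fall between the two limits remains open.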